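The source may report more compounds than this note shows. Statements on the series, on what has been measured and on what is new or still open speak of the compounds shown alone.

Working notes on a short series tested in an assay on isolated protein for antagonist activity at Rap guanine nucleotide exchange factor 4 (Homo sapiens), read by fluorescence and cAMP accumulation; a lower number here means a stronger inhibitor, a higher number a weaker inhibitor. Compound 1 `CCc1cccn1S(=O)(=O)c1ccc(C)cc1` carries a single methyl on its six-membered aromatic ring of carbon only; in this assay compound 1 gives 4000 nM. Compound 2 `CCc1cccn1S(=O)(=O)c1ccccc1C` also carries a single methyl on that ring, and in this assay compound 2 gives 5300 nM. Compound 2 stands at the higher of the two numbers, but its gap to compound 1 is within the usual scatter of measurements of this kind, so the two compounds cannot be separated on the data at hand.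

Compound 3 `CCc1cccn1S(=O)(=O)c1ccc(C)cc1C` has not yet been measured in this assay. Relative to compound 2 it shows (methyl in place of hydrogen on an aromatic carbon), so that compound 3 carries both methyls that compound 1 and compound 2 carry singly. Within the data shown here, no step between measured compounds is available to calibrate this change, and the two single-methyl compounds sit on top of each other. The expectation is therefore a step from compound 2 to compound 3 of a 1.4-fold lower number from compound 2 to compound 3 (0.14 log units; within the scatter), not beyond the scatter. Compound 3 is expected at 3800 nM, with a range of 1300 nM to 11000 nM.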

Compound 3, half-maximal inhibitory concentration: 1300 nM
For compound 3 the middle estimate is 2.9-fold (0.47 log units) above the measured one; measured number inside the range.
By their numbers in this assay, from the lowest: compound 3; then compounds 1 and 2 (each within the scatter of the next).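

With a methyl in place of hydrogen on an aromatic carbon, meta to a methyl group and para to a large group, this assay shows a 4.1-fold lower number from compound 2 to compound 3 (0.61 log units; beyond the scatter) and thereby gives the first separation in the series beyond the scatter. The same comparison made from the other single-methyl compound shows a 3.1-fold lower number from compound 1 to compound 3 (0.49 log units; beyond the scatter) and points the same way, so compound 3 with both methyls stands apart from compound 1 and from compound 2, although those two could not be separated from each other. The position therefore accepts a methyl with a stronger inhibitor as the outcome when the other methyl is already on the ring, but no measurement at hand bears on the reason for this.

The compounds shown leave open how a ring with hydrogen at both places would stand, and so whether each methyl contributes on its own or only the pair separates from the rest. They also leave open whether an ethyl group, a methoxy group, chlorine or an amine at this position would follow the methyl or break from it.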